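A few compounds are considered here, and "the series" means these few. Any claim that something is new, unique, unknown or untested is made for them only; others in the source may bear on it.

Three compounds of the series have numbers in an assay on isolated protein for activation of cGMP-dependent protein kinase 1 (Homo sapiens), read by ADP-Glo, with stated times of 30 min and 2 h, in the presence of a further agent that is not named here; a lower number here means that less compound is needed, a higher number that more compound is needed for the effect. Compound 1 `O=C(O)C12CC(CN3CCC[C@H](O[C@H](CO)c4cc(Cl)cc(Cl)c4)[C@@H]3c3ccccc3)(C1)C2` gives 12000 nM and stands second highest of the three. Its nearest neighbour is compound 3 `Cc1cc(C(=O)O)ccc1CN1CCC[C@H](O[C@H](CF)c2cc(Cl)cc(Cl)c2)[C@@H]1c1ccccc1`, which gives 9100 nM; the two lie within the usual scatter of each other. The furthest is compound 2 `Cc1cc(C(=O)O)ccc1CN1CC[C@H](OC(CO)c2cc(Cl)cc(Cl)c2)[C@@H]1c1ccccc1`, which gives 133000 nM, a number well beyond the scatter from that of compound 1. No pair among these three differs in a single place, so no step between measured compounds can be isolated.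

Compound 4 `Cc1cc(C(=O)O)ccc1C(=O)N1CCC[C@H](O[C@H](CO)c2cc(Cl)cc(Cl)c2)[C@@H]1c1ccccc1` has not been measured. It differs from compound 1 by a group of 12 heavy atoms (9 carbon, 3 oxygen; one six-membered aromatic ring of carbon only) in place of a group of 9 heavy atoms (7 carbon, 2 oxygen; 2 four-membered non-aromatic rings of carbon only), on an amine nitrogen in a ring. The entering group resembles the aromatic acid group carried by compound 3, but here it is attached through a carbonyl on the ring nitrogen. Compound 3 with a related aromatic acid group on a ring of the same size gives 9100 nM, which suggests the aromatic acid is tolerated in this assay. Going by these compounds, the carbonyl attachment is untested, so the direction is uncertain and a step of modest size, possibly none beyond the scatter, is expected. For compound 4 the expected value in this assay is 20000 nM, with a range from 5000 nM to 80000 nM. The estimated step from compound 1 to compound 4 is a 1.7-fold higher number from compound 1 to compound 4 (0.22 log units; within the scatter).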

Compound 4, half-maximal effective concentration: > 200000 nM
Compound 4 was reported as a limit; the forecaster's own chance of this, stated with the estimate: 15%; middle value at least 10-fold (1.00 log units) from the limit.
By their numbers in this assay, from the lowest: compounds 3 and 1 (each within the scatter of the next); then compound 2. At a limit, above all of these: compound 4.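

On the amine nitrogen in the ring, the group of 12 heavy atoms with its six-membered aromatic ring, in place of the group of 9 heavy atoms with 2 four-membered rings, gives in this assay an at least 16-fold higher number from compound 1 to compound 4 (1.22 log units; beyond the scatter). For the compounds shown here, this is the first single-place step, and it shows that the read-out is sensitive to the group at this position, which the three earlier compounds could not show. The reading for compound 4 is a limit of the assay and not a number: the limit of > 200000 nM in this assay, at which 1 of the 4 values shown sits.

Compound 4 changes the ring system and the carbonyl attachment in one step, so the share of each stays unresolved. Also open, going by these compounds, is how the series reads with a sulfonyl link on this nitrogen, or with an amine in place of the carboxylic acid.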